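Two Close Values and One Small Chain Change

The source may hold more compounds than are shown below. What is called first, only, known or untested is meant among the compounds shown, and "the series" means these compounds.

Compound 1 `C=CCCCCOc1ccccc1-c1cnc(OCCC=C)n1C`: 19000 nM
Compound 2 `CCCCCCOc1ncc(-c2ccccc2OC)n1C`: 33000 nM

In a functional assay on PC-3 cells (Homo sapiens) for inhibition, read by colorimetric assay and MTT assay, with a stated time of 72 h (a lower number here means a stronger inhibitor, a higher number a weaker inhibitor), compound 2 gives 33000 nM. This lies within the usual scatter of compound 1 at 19000 nM, so the two cannot be told apart. Compound 3 `C=CCCCCOc1ncc(-c2ccccc2OC)n1C` carries vinyl in place of ethyl on a saturated chain carbon, four bonds along the chain from an oxygen on an aromatic ring. Among the compounds with values here, no measured pair shows this change on its own, so no step beyond the scatter is expected in this assay. The expected step is a 1.2-fold lower number from compound 2 to compound 3 (0.09 log units; within the scatter). For compound 3 the estimated value is 27000 nM, with an expected range of 14000 nM to 50000 nM.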

Compound 3, half-maximal inhibitory concentration: 24000 nM
Compound 3: middle estimate off by 1.1-fold (0.05 log units), on the high side; measured number inside the range.
By their numbers in this assay, from the lowest: compounds 1, 3 and 2 (each within the scatter of the next).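

Within the data shown here, this pair is the first to isolate vinyl in place of ethyl on a saturated chain carbon, four bonds along the chain from an oxygen on an aromatic ring. In this assay, the change gives a 1.4-fold lower number from compound 2 to compound 3 (0.14 log units; within the scatter). At this place, then, the double bond outside the aromatic rings does not give a difference that can be told apart from repeat-measurement noise. No measured evidence here bears on this result. Still open, on these data alone, is whether an amine, a carboxylic acid or a longer chain at this place would give a step beyond the scatter.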